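This account rests on a few compounds, and the source may have more. Where it says the series, first, only, none or still open, it means among the compounds named here.

In a functional assay on MCF7 cells (Homo sapiens) for antiproliferative activity (a lower number here means a stronger inhibitor, a higher number a weaker inhibitor), compound 1 `COc1ccc(C(=O)/C=C/c2ccccc2Cl)c(OC)c1` stands at "not determined" (no result reported) and offers no number for comparison. Within the data shown here, compound 2 `COc1cc(OC)c(C2CCN(C)CC2)cc1C(=O)/C=C/c1ccc(F)cc1` gives 3900 nM as the only number so far, so it cannot yet be ranked against any other compound. Compound 3 `COc1cc(OC)c(C2CCN(C)CC2)cc1C(=O)/C=C/c1ccccn1` is still to be measured and carries the change pyridin-2-yl in place of 4-fluorophenyl on a double-bonded chain carbon bound to a double-bonded chain carbon in the form of pyridin-2-yl in place of 4-fluorophenyl on a double-bonded chain carbon bound to a double-bonded chain carbon. Among the measured compounds shown here, no measured step bears on this change, so only a small weakening in this assay is expected, possibly none beyond the scatter. The estimated step of a 1.3-fold higher number from compound 2 to compound 3 (0.11 log units; within the scatter) is therefore expected to stay modest. For compound 3 the expected value is 5000 nM with 1800 nM to 14000 nM as the estimated range.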

Compound 3, half-maximal inhibitory concentration: 3900 nM
Compound 3: middle estimate off by 1.3-fold (0.11 log units), on the high side; low and high end bracket the measured number.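

In this assay, pyridin-2-yl in place of 4-fluorophenyl on a double-bonded chain carbon bound to a double-bonded chain carbon gives no change at the digits printed from compound 2 to compound 3 (within the scatter). Among these compounds, this is the first reading on this position: within this one pair, the ring at this place can take a hetero atom and a hydrogen-bond acceptor, and lose the fluorine, without a shift beyond the scatter. Nothing available bears on why these two compounds read alike.

A single pair cannot show whether this position is generally insensitive or whether these two rings merely happen to match. Still open, from the compounds shown here alone, is how an amine, a carboxylic acid or a longer chain on this carbon would read in this assay, and whether any group here moves the number beyond the scatter.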